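This account rests on a few compounds, and the source may have more. Where it says the series, first, only, none or still open, it means among the compounds named here.

In a physicochemical assay for acid dissociation, compound 1 (`c1ccc(COc2noc3c2CNCC3)cc1`) gives 7.5 and compound 2 (`CC(C)Oc1noc2c1CNCC2`) gives 7.5 so the two stand level within the usual scatter of repeated measurements. Compound 3 (`CCCOc1noc2c1CNCC2`) has yet to be measured. It differs from compound 2 in one place (propyl in place of isopropyl on an oxygen on an aromatic ring): propyl in place of isopropyl on an oxygen on an aromatic ring, with the same atoms joined differently. For the measured compounds named here, no measured pair shows this exact change, so any forecast rests on little evidence. Compound 1 and compound 2 carry different groups on that oxygen, and compound 2 at 7.5 still sits level with compound 1. On that basis, the expected step (no change at the digits printed from compound 2 to compound 3 (within the scatter)) is none beyond the scatter, in either direction. In this assay compound 3 is estimated at 7.5 with an expected range of 7.2 to 7.8 for a single measurement.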

Compound 3, acid dissociation constant: 7.6
For compound 3 the middle estimate is 0.10 log units below the measured one; low and high end bracket the measured number.
By their numbers in this assay, from the lowest: compounds 1, 2 and 3 (each within the scatter of the next).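

In this assay, for the compounds shown here, the change from isopropyl to propyl on the oxygen gives a number 0.10 log units higher from compound 2 to compound 3 (within the scatter) and is the first step measured for a single change at this position. Moving from one arrangement of the same three carbons to the other therefore leaves the two compounds inseparable in this read-out, which the comparison of compound 1 with compound 2 could not show directly, since those two carry groups that differ in their atoms as well. Nothing measured here explains why these two groups read alike.

On these data alone, it remains open whether a group of another kind on this oxygen, such as a chain ending in an amine or a carboxylic acid, would shift the number beyond the scatter. A much longer chain at this position is equally untested by the compounds shown.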